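Methyl in Place of Isopropyl: Expected Effect on Inhibition

The compounds below may be only part of what the source reports. "The series", "measured", "known", "first", "only" and "open" are said of these compounds alone.

Compound 1 `Cc1ccc(Nc2nc(SCc3cn(CC(=O)NC(=O)Nc4ccccn4)nn3)nc(-c3ccc(C(C)C)cc3)c2C#N)cc1`, > 64000 nM in a functional assay on MCF7 cells (Homo sapiens) for inhibition, read by MTT assay, with a stated time of 72 h; on this read-out higher numbers stand for weaker inhibition and lower numbers for stronger inhibition; this value is a limit of the assay.
Compound 2 `COc1cc(-c2nc(SCc3cn(CC(=O)NC(=O)Nc4ccccn4)nn3)nc(Nc3ccc(C(C)C)cc3)c2C#N)cc(OC)c1OC`, 30900 nM in this assay.

For the measured compounds named here, compound 2 holds the only numerical value shown; the other value is a limit (the limit of > 64000 nM in this assay, at which 1 of the 2 values shown sits). Compound 3 `COc1cc(-c2nc(SCc3cn(CC(=O)NC(=O)Nc4ccccn4)nn3)nc(Nc3ccc(C)cc3)c2C#N)cc(OC)c1OC` differs from compound 2 by methyl in place of isopropyl on an aromatic carbon. Going by the values given here, no measured step of this kind is available, so any expectation rests on compound 2 alone. A shift no larger than the usual scatter, in either direction, is expected, which the step of a 1.1-fold higher number from compound 2 to compound 3 (0.05 log units; within the scatter) reflects. Compound 3 is estimated at 35000 nM, between 12000 nM and 90000 nM.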

Compound 3, half-maximal inhibitory concentration: 21000 nM
Estimate against measurement, compound 3: 1.7-fold (0.22 log units) above; the range from low to high includes it.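

In this assay, methyl in place of isopropyl on the aromatic carbon gives a 1.5-fold lower number from compound 2 to compound 3 (0.17 log units; within the scatter), so swapping these two alkyl groups leaves the read-out unresolved. The other aromatic group on the shared core does register, since 3,4,5-trimethoxyphenyl in place of 4-isopropylphenyl gives an at least 3.0-fold lower number from compound 1 to compound 3 (0.48 log units; beyond the scatter). The figure for compound 1 is a limit of the assay, so that step has no upper size: the limit of > 64000 nM in this assay, at which 1 of the 3 values shown sits.

As far as these compounds go, whether an amine, a hydroxyl group or a chlorine in place of methyl on this ring would shift the number beyond the scatter remains open.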